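Amide aryl swap in a weakly antiproliferative anilide series

The source may hold more compounds than are shown below. What is called first, only, known or untested is meant among the compounds shown, and "the series" means these compounds.

Compound 2 `Cc1cc(Cl)ccc1C(=O)Nc1ccc(Cl)c(-c2nnc3c(Cl)cccn23)c1` is one of three anilides built on a shared core. In a functional assay on HeLa cells (Homo sapiens) for antiproliferative activity, read by MTT assay, with a stated time of 72 h (on this read-out lower numbers stand for stronger inhibition and higher numbers for weaker inhibition), compound 2 gives only a limit of the assay, > 100000 nM. Compound 1 `O=C(Nc1ccc(Cl)c(-c2nnc3c(Cl)cccn23)c1)c1ccc(C(F)(F)F)cc1F` gives 61900 nM in this assay. Compound 3 `O=C(Nc1ccc(Cl)c(-c2nnc3c(Cl)cccn23)c1)c1ccc(C(F)(F)F)cc1Cl` likewise reaches only the limit, > 100000 nM. Among the measured compounds shown here, the single measured step, an at least 1.6-fold higher number from compound 1 to compound 3 (0.20 log units; that floor lies within the scatter), concerns another part of the molecule and is itself capped, because the limit of > 100000 nM in this assay, at which 2 of the 3 values shown sit, holds two of the three values. Compound 4 `O=C(Nc1ccc(Cl)c(-c2nnc3c(Cl)cccn23)c1)c1cccnc1Cl` differs from compound 2 by 2-chloropyridin-3-yl in place of 4-chloro-2-methylphenyl on a carbonyl carbon. For the measured compounds named here, no measured step bears directly on this change, so no movement beyond the scatter is expected in this assay, a number no higher from compound 2 to compound 4 (the limit leaves the size open). Compound 4 is accordingly estimated at 100000 nM, within 30000 nM to 300000 nM.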

Compound 4, half-maximal inhibitory concentration: 87500 nM
Compound 4: the middle estimate sits 1.1-fold (0.06 log units) above what was measured; the measured number falls inside the stated range.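

Putting 2-chloropyridin-3-yl in place of 4-chloro-2-methylphenyl on a carbonyl carbon gives, in this assay, an at least 1.1-fold lower number from compound 2 to compound 4 (0.05 log units; that floor lies within the scatter). With a six-membered aromatic ring holding 1 hetero atom at this place, compound 4 gives a measured number, 87500 nM. As far as these compounds go, the size of the step stays open because one end of it is a limit: the limit of > 100000 nM in this assay, at which 2 of the 4 values shown sit.

Still open, from the compounds shown here alone, is what an amine or a carboxylic acid on this aromatic ring would do to the number. Also open, going by these compounds, is whether a saturated piperidine ring at this place would read differently.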